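This account rests on a few compounds, and the source may have more. Where it says the series, first, only, none or still open, it means among the compounds named here.

Compound 1 `Cc1occc1-c1nnc2sc(-c3cc(O)nc(O)c3)nn12` — 11.4%
Compound 2 `COc1ccc(Cc2nnc3n2NC(c2ccco2)S3)cc1OC` — 17.5%
Compound 3 `COc1ccc(Cc2nnc3n2NC(c2ccc([N+](=O)[O-])o2)S3)cc1OC` — 17.6%

Three compounds were read in a functional assay on the whole organism (strain Wistar Albino) for inhibition, with Rattus norvegicus as the target, read by paw edema, with a stated time of 2 h, at a dose of 20 mg/kg; on this read-out lower numbers stand for less inhibition and higher numbers for more inhibition at the one dose given (going by the name of the read-out). Compound 3 gives 17.6%, and its figure cannot be separated from that of compound 2 or that of compound 1, since both neighbours lie within the usual scatter of it. Within the data shown here, the one measured step that differs in a single place, from compound 2 to compound 3, is a number 0.1 percentage points higher from compound 2 to compound 3 (within the scatter), a nitro in place of hydrogen on an aromatic carbon.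

Compound 4 `COc1ccc(Cc2nnc3n2NC(c2cccn2C)S3)cc1OC` has not yet been measured. It differs from compound 3 by 1-methyl-1H-pyrrol-2-yl in place of 5-nitrofuran-2-yl on a saturated ring carbon. That change sits on the same saturated ring carbon whose attached group was altered between compound 2 and compound 3, and that alteration left the read-out unmoved. On that single comparison, the step to compound 4 is expected to stay within the scatter in either direction. Compound 4 is therefore estimated to give 17%, with a range from 8% to 26%. The expected step, a number 0.6 percentage points lower from compound 3 to compound 4 (within the scatter), is no change beyond the scatter.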

Compound 4, a percentage reported as inhibition, in the whole organism at one dose (the size of the read-out at that dose, not a potency): 15.8%
Beside the measured number, compound 4's estimate is 1.2 percentage points above it; the measured number falls inside the stated range.
By their numbers in this assay, from the lowest: compounds 1, 4, 2 and 3 (each within the scatter of the next).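

In this assay, putting 1-methyl-1H-pyrrol-2-yl on the saturated ring carbon in place of 5-nitrofuran-2-yl gives a number 1.8 percentage points lower from compound 3 to compound 4 (within the scatter) and in place of furan-2-yl gives a number 1.7 percentage points lower from compound 2 to compound 4 (within the scatter) as the second reading of the same change. The earlier compounds shown here had only compared two furan groups at this carbon, whereas this pair shows that a ring with nitrogen and a methyl group in place of the ring oxygen also cannot be separated from them. Nothing available explains this result or bears on it.

From the compounds shown here alone, all three groups at this carbon are five-membered aromatic rings with one hetero atom, so whether an amine, a carboxylic acid or a longer chain there would move the number in this assay beyond the scatter stays open. Each number is also a reading at a single dose, which leaves the potency of these compounds open.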